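This account rests on a few compounds, and the source may have more. Where it says the series, first, only, none or still open, it means among the compounds named here.

Series on the shared core of compound 1 `O=C(COc1ccc(C(=O)/C=C/c2ccc(F)c(F)c2)cc1)N[C@H]1CCOC1=O`, varied at the aryl end of the enone. In a functional assay on MGC-803 cells (Homo sapiens) for antiproliferative activity, read by MTT assay, with a stated time of 72 h (a higher number here means a weaker inhibitor, a lower number a stronger inhibitor), compound 1 gives only a limit, > 64000 nM, which is the assay limit (the limit of > 64000 nM in this assay, at which 1 of the 3 values shown sits). Compound 2 `CC(C)(C)c1ccc(/C=C/C(=O)c2ccc(OCC(=O)N[C@H]3CCOC3=O)cc2)cc1` gives 17200 nM in this assay. Compound 3 `CC(C)c1ccc(/C=C/C(=O)c2ccc(OCC(=O)N[C@H]3CCOC3=O)cc2)cc1` gives 16800 nM in this assay; of the two numbers shown it holds the lower, compound 2 being nearest, and the pair differ by a 1.0-fold lower number from compound 2 to compound 3 (0.01 log units; within the scatter), within the scatter. The steps of an at least 3.7-fold lower number from compound 1 to compound 2 (0.57 log units; beyond the scatter) and an at least 3.8-fold lower number from compound 1 to compound 3 (0.58 log units; beyond the scatter) are beyond the scatter, though both are bounds only, one side being a limit.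

Compound 4 `O=C(COc1ccc(C(=O)/C=C/c2ccccc2)cc1)N[C@H]1CCOC1=O` differs from compound 3 by hydrogen in place of isopropyl on an aromatic carbon. Within the data shown here, no measured step removes the alkyl group altogether; the step of a 1.0-fold lower number from compound 2 to compound 3 (0.01 log units; within the scatter) shows only that tert-butyl and isopropyl behave alike, while compound 1 shows the 3,4-difluorophenyl end to be weaker by an at least 3.8-fold lower number from compound 1 to compound 3 (0.58 log units; beyond the scatter). Compound 4 is therefore expected to give a higher number than compound 3, by a 2.1-fold higher number from compound 3 to compound 4 (0.32 log units; beyond the scatter), with a real chance of only a limit. The estimate for compound 4 in this assay is 35000 nM, with a range of 14000 nM to 90000 nM.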

Compound 4, half-maximal inhibitory concentration: > 64000 nM
Compound 4 was reported as a limit; the forecaster's own chance of this, stated with the estimate: 30%; at least 1.8-fold (0.26 log units) between middle value and limit.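

Among these compounds, the change 4-isopropylphenyl to phenyl is the first step here that removes the alkyl group altogether, and in this assay it gives an at least 3.8-fold higher number from compound 3 to compound 4 (0.58 log units; beyond the scatter); hydrogen in place of tert-butyl gives an at least 3.7-fold higher number from compound 2 to compound 4 (0.57 log units; beyond the scatter). Among the four compounds shown, numbers below the limit belong only to compound 2 and compound 3, so a bare phenyl end does not retain what either alkyl group gives. Compound 4 is reported as a limit, as is compound 1, so both steps above are bounds and the step from one limit to the other cannot be read: the limit of > 64000 nM in this assay, at which 2 of the 4 values shown sit.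

From the compounds shown here alone, compound 2 and compound 3 lie within the scatter of each other, so how far the alkyl group can shrink stays open. A methyl or ethyl group at this place, or a methoxy or dimethylamino group, would show whether an alkyl group is required.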